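Aryl ether variation on the shared core

The source may hold more compounds than are shown below. What is called first, only, known or untested is meant among the compounds shown, and "the series" means these compounds.

Compound 1 `Cn1cc(-c2cc(C(C)(C)O)ccc2Oc2ccc(F)cc2F)c2cc(C(=O)NCc3ccc(C(=O)Nc4ccccc4N)cc3)[nH]c2c1=O` gives 90 nM in a functional assay on MV4-11 cells (Homo sapiens) for antiproliferative activity, read by CCK-8 assay, with a stated time of 72 h (on this read-out higher numbers stand for weaker inhibition and lower numbers for stronger inhibition), standing second highest of the three numbers. Compound 3 `Cn1cc(-c2ccccc2Oc2ccccc2)c2cc(C(=O)NCc3ccc(C(=O)Nc4ccccc4N)cc3)[nH]c2c1=O` gives 80 nM, within the scatter of compound 1, while compound 2 `Cn1cc(-c2ccccc2F)c2cc(C(=O)NCc3ccc(C(=O)Nc4ccccc4N)cc3)[nH]c2c1=O` gives 230 nM, a higher number beyond the scatter. For the measured compounds named here, the one measured step in this region, a 2.9-fold lower number from compound 2 to compound 3 (0.46 log units; beyond the scatter), concerns the aryl ether itself rather than its substituents. Compound 4 `Cc1cc(F)cc(C)c1Oc1ccc(C(C)(C)O)cc1-c1cn(C)c(=O)c2[nH]c(C(=O)NCc3ccc(C(=O)Nc4ccccc4N)cc3)cc12` differs from compound 1 by 4-fluoro-2,6-dimethylphenyl in place of 2,4-difluorophenyl on an oxygen on an aromatic ring. Going by the values given here, no measured pair exchanges substituents on the aryl ether, so the step from compound 2 to compound 3 only shows that the ether region tolerates change without loss. A step within the scatter is therefore expected, a 1.1-fold higher number from compound 1 to compound 4 (0.05 log units; within the scatter), and compound 4 is estimated at 100 nM, between 40 nM and 250 nM.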

Compound 4, half-maximal inhibitory concentration: 240 nM
For compound 4 the middle estimate is 2.4-fold (0.38 log units) below the measured one; the measured number falls inside the stated range.
By their numbers in this assay, from the lowest: compounds 3 and 1 (each within the scatter of the next); then compounds 2 and 4 (each within the scatter of the next).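

In this assay, 4-fluoro-2,6-dimethylphenyl in place of 2,4-difluorophenyl on the ether oxygen gives a 2.7-fold higher number from compound 1 to compound 4 (0.43 log units; beyond the scatter) as a modest loss. For the compounds shown here, this is the first measured exchange of substituents on the aryl ether, and it shows that this position responds to them, which the earlier step from fluoro to phenoxy could not show.

As far as these compounds go, whether the loss follows the two methyl groups or the missing fluorine stays open, as does how an amine or a carboxylic acid on this ring would read. No measurement at hand bears on the reason for this step.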